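The source may report more compounds than this note shows. Statements on the series, on what has been measured and on what is new or still open speak of the compounds shown alone.

Of the compounds shown here, two have been tested so far in a functional assay on SMMC-7721 cells (Homo sapiens) for cytotoxicity, read by MTT assay, with a stated time of 24 h; on this read-out lower numbers stand for stronger inhibition and higher numbers for weaker inhibition. Compound 1 (`CN1C/C(=C\c2cccnc2)C(=O)/C(=C/c2ccccc2C(F)(F)F)C1`) gives 3900 nM and compound 2 (`CN1C/C(=C\c2ccncc2)C(=O)/C(=C/c2ccccc2F)C1`) gives 7000 nM, so compound 2 stands within the usual scatter of compound 1. Compound 3 (`CN1C/C(=C\c2ccncc2)C(=O)/C(=C/c2ccccc2C(F)(F)F)C1`) is built from compound 2 by placing trifluoromethyl in place of fluoro on an aromatic carbon, ortho to a large group: trifluoromethyl in place of fluoro on an aromatic carbon. Among the measured compounds shown here, no two measured compounds differ in one place only, so the data offer no direct guide to this change. Compound 1 also carries trifluoromethyl and gives 3900 nM, so the expectation is for no step beyond the scatter, with a slight lean towards a lower number. The estimated step is a 1.5-fold lower number from compound 2 to compound 3 (0.16 log units; within the scatter). For compound 3 the expected value is 4800 nM, with an estimated range of 2200 nM to 10000 nM.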

Compound 3, half-maximal inhibitory concentration: 4100 nM
Beside the measured number, compound 3's estimate is 1.2-fold (0.07 log units) above it; the range from low to high includes it.
By their numbers in this assay, from the lowest: compounds 1, 3 and 2 (each within the scatter of the next).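

In this assay, the first one-place comparisons become possible. Trifluoromethyl in place of fluoro on an aromatic carbon, ortho to a large group, gives a step within the scatter (a 1.7-fold lower number from compound 2 to compound 3 (0.23 log units; within the scatter)), so this larger group leaves the read-out without a clear change at this position. With trifluoromethyl in place, pyridin-4-yl in place of pyridin-3-yl also stays within the scatter (a 1.1-fold higher number from compound 1 to compound 3 (0.02 log units; within the scatter)), and no information is available to explain either result.

What the compounds shown leave open is whether a clearly different group on this aromatic carbon, such as an amine, a carboxylic acid or a longer chain, would move the number beyond the scatter. They also leave open whether the pyridin-4-yl and pyridin-3-yl exchange would stay within the scatter with fluoro in place of trifluoromethyl.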